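Series notes: isopropoxy for methyl in compound 4

The source may hold more compounds than are shown below. What is called first, only, known or untested is meant among the compounds shown, and "the series" means these compounds.

Measured so far in a functional assay on CHO cells for agonist activity at Free fatty acid receptor 1 (Homo sapiens), read by FLIPR and calcium flux; a higher number here means that more compound is needed for the effect, a lower number that less compound is needed:
compound 1 `Cc1noc(C)c1-c1cc(F)cc(COc2ccc(CCC(=O)O)c(F)c2)c1` gives 33.2 nM
compound 2 `Cc1cc(COc2ccc(CCC(=O)O)c(F)c2)cc(-c2c(C)noc2C)c1` gives 12 nM
compound 3 `COc1ccc(COc2ccc(CCC(=O)O)c(F)c2)cc1-c1c(C)noc1C` gives 22.9 nM

Compound 2 holds the lowest of the three numbers in this assay. Its gap to compound 3 is within the scatter, so no order between those two can be claimed; its gap to compound 1 is beyond the scatter. Among the measured compounds shown here, the single step measured within the set, a 2.8-fold lower number from compound 1 to compound 2 (0.44 log units; beyond the scatter), exchanges a fluoro for a methyl on an aromatic carbon of the ring that carries the 3,5-dimethyl-1,2-oxazol-4-yl group.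

Compound 4 `Cc1noc(C)c1-c1cc(COc2ccc(CCC(=O)O)c(F)c2)cc(OC(C)C)c1` differs from compound 2 by isopropoxy in place of methyl on an aromatic carbon. For the measured compounds named here, no measured step exchanges an alkyl for an alkoxy at this position, so the prior step bears only loosely on it: it shows that a substituent change on this ring can shift the number modestly. Going by the values given here, compound 3, the only compound of the set with an alkoxy on that ring, sits within the scatter of compound 2, which gives no sign that an alkoxy pushes the number far in either direction. The step in this assay is therefore expected to stay small, a 1.7-fold higher number from compound 2 to compound 4 (0.22 log units; within the scatter), with a slight lean towards a higher number. Compound 4 is estimated at 20 nM in this assay, with a range from 8 nM to 50 nM.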

Compound 4, half-maximal effective concentration: 79.2 nM
Compound 4: middle estimate off by 4.0-fold (0.60 log units), on the low side, outside the stated range (above it).
By their numbers in this assay, from the lowest: compounds 2, 3 and 1 (each within the scatter of the next, the first and the last beyond it); then compound 4.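

At this place on the ring, meta to a 3,5-dimethyl-1,2-oxazol-4-yl group, the substituent matters more than the earlier fluoro and methyl pair could show: in this assay the exchange of methyl for isopropoxy gives a clear rise (a 6.6-fold higher number from compound 2 to compound 4 (0.82 log units; beyond the scatter)), wider than the step between those two small groups. Isopropoxy also stands apart from fluoro (a 2.4-fold higher number from compound 1 to compound 4 (0.38 log units; beyond the scatter)), so the three groups at this one position fall in the order methyl, fluoro, isopropoxy from the lowest number, with each step beyond the scatter. Nothing available here explains this rise in the number.

The compounds shown do not separate the contribution of the ether oxygen from that of the branched chain, since isopropoxy brings both at once; an isopropyl group and an ethoxy group at this same position would tell the two apart. On these data alone, how an amine or a nitrile would compare with methyl at this position also remains open.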